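From chloro to bromo on compound 1

The source may hold more compounds than are shown below. What is called first, only, known or untested is meant among the compounds shown, and "the series" means these compounds.

Measured so far:
Compound 1 `CC1=NN(C(=O)CCl)C(c2cc(Cl)ccc2O)C1`: 12300 nM
Compound 2 `CC1=NN(C(=O)c2ccc(F)cc2)C(c2ccccc2O)C1`: 35400 nM

In a functional assay on MGC-803 cells (Homo sapiens) for antiproliferative activity, read by MTT assay, with a stated time of 48 h (on this read-out lower numbers stand for an effect already at smaller amounts and higher numbers for an effect only at larger amounts of compound), compound 1 has the lower of the two numbers, and the gap up to compound 2 lies beyond the usual scatter. These two compounds differ in more than one place, so their gap isolates no single change. Compound 3 `CC1=NN(C(=O)CCl)C(c2cc(Br)ccc2O)C1` has bromo in place of chloro on an aromatic carbon. Among the measured compounds shown here, no measured pair shows this swap, and the expectation in this assay is a step no larger than the scatter, in neither clear direction. The expected change is a 1.1-fold lower number from compound 1 to compound 3 (0.05 log units; within the scatter). Compound 3 is estimated at 11000 nM, within a range of 5000 nM to 25000 nM.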

Compound 3, half-maximal effective concentration: 10500 nM
Compound 3: the middle estimate sits 1.0-fold (0.02 log units) above what was measured; the range from low to high includes it.
By their numbers in this assay, from the lowest: compounds 3 and 1 (each within the scatter of the next); then compound 2.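

In this assay, among the compounds shown here, the one single-place comparison available gives a 1.2-fold lower number from compound 1 to compound 3 (0.07 log units; within the scatter) when bromo replaces chloro on the aromatic carbon para to a hydroxy group. At this position, then, the two groups cannot be told apart on this read-out, and a heavier atom of this kind brings no clear gain or loss. No supporting measurement bears on this result. Still open, going by these compounds, is whether a different kind of group at this place, such as a methoxy group or an amine, would shift the number beyond the scatter.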